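One Methyl Group Added Twice on Related Cores

The source may report more compounds than this note shows. Statements on the series, on what has been measured and on what is new or still open speak of the compounds shown alone.

Measured so far:
- compound 1 `Cc1cn(-c2csc(Nc3ccc(Br)cc3)n2)c(C)n1`, in a functional assay on RKO cells (Homo sapiens) for cytotoxicity, read by resazurin assay, with a stated time of 72 h; a higher number here means a weaker inhibitor, a lower number a stronger inhibitor: 45000 nM
- compound 2 `Cc1nccn1-c1csc(Nc2ccc(Br)cc2)n1`: > 100000 nM, a limit of the assay
- compound 3 `c1ccc(Nc2nc(-n3ccnc3)cs2)cc1`: > 100000 nM, a limit of the assay

Compound 2 and compound 3 both sit at the limit of > 100000 nM in this assay, at which 2 of the 3 values shown sit. The difference between the two cores of compound 2 and compound 3 is not broken down here. The change methyl in place of hydrogen on an aromatic carbon gave an at least 2.2-fold lower number from compound 2 to compound 1 (0.34 log units; beyond the scatter). Compound 4 `Cc1nccn1-c1csc(Nc2ccccc2)n1` carries the same kind of change, (methyl in place of hydrogen on an aromatic carbon), though the place differs: here the new group sits between two ring nitrogen atoms and next to the ring atom that bears a large group. As far as these compounds go, because compound 3 gives only a limit, > 100000 nM, the starting point is unknown. Compound 4 is expected to reach about 100000 nM, with an estimated a number no higher from compound 3 to compound 4 (the limit leaves the size open), and a limit remains likely.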

Compound 4, half-maximal inhibitory concentration: > 100000 nM
Compound 4: a limit, no number; the forecaster's own chance of this, stated with the estimate: 60%; the middle value lies on the limit itself.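

Compound 4 gives only a limit, as do compound 2 and compound 3, so neither step to compound 4 can be read: the limit of > 100000 nM in this assay, at which 3 of the 4 values shown sit.
As far as these compounds go, whether the methyl group or the bromo changes the number on these cores stays open.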